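A few compounds are considered here, and "the series" means these few. Any claim that something is new, unique, unknown or untested is made for them only; others in the source may bear on it.

Measured compounds in an assay on HEK293 cells for displacement of a labelled ligand from transient receptor potential cation channel subfamily V member 1 (Homo sapiens); a lower number here means a stronger inhibitor, a higher number a weaker inhibitor:
compound 1 `Cc1ccccc1N1CCC(C(=O)Nc2ccc3c(c2)NC(=O)CO3)CC1` — 61 nM
compound 2 `O=C1COc2ccc(NC(=O)C3CCN(c4cc(F)c(F)c(F)c4)CC3)cc2N1` — 49 nM

On these numbers compound 2 stands beside compound 1, the step of a 1.2-fold lower number from compound 1 to compound 2 (0.10 log units; within the scatter) lying within the scatter. Compound 3 `Cc1c(Cl)cccc1N1CCC(C(=O)Nc2ccc3c(c2)NC(=O)CO3)CC1` differs from compound 2 by 3-chloro-2-methylphenyl in place of 3,4,5-trifluorophenyl on an amine nitrogen in a ring. For the measured compounds named here, the only measured step that bears on an exchange at this position is that from compound 1 to compound 2, and it stayed within the scatter; no step beyond the scatter is therefore expected in this assay, the estimate meaning a 1.0-fold higher number from compound 2 to compound 3 (0.01 log units; within the scatter). Compound 3 is estimated at 50 nM, with a range from 20 nM to 150 nM.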

Compound 3, inhibition constant: 100 nM
Compound 3: middle estimate off by 2.0-fold (0.30 log units), on the low side, and the stated range covers the measured number.
By their numbers in this assay, from the lowest: compounds 2, 1 and 3 (each within the scatter of the next, the first and the last beyond it).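

In this assay, for the compounds shown here, the exchange on the amine nitrogen in a ring gives a 2.0-fold higher number from compound 2 to compound 3 (0.31 log units; beyond the scatter) as the first step beyond the scatter at this position, so the choice of aryl group can move the number, if modestly. Chloro in place of hydrogen on an aromatic carbon gives a 1.6-fold higher number from compound 1 to compound 3 (0.21 log units; within the scatter) and stays within the scatter, so that single addition is not resolved on its own.

Open, from the compounds shown here alone, is how a cyclohexyl group on this nitrogen, or a phenyl ring carrying an amine or a carboxylic acid, would read here. Nothing measured explains the step from 3,4,5-trifluorophenyl to 3-chloro-2-methylphenyl.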